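A few compounds are considered here, and "the series" means these few. Any claim that something is new, unique, unknown or untested is made for them only; others in the source may bear on it.

Measured compounds:
compound 2 `Cc1c(OCCCCOc2ccc(C(=O)O)cc2)ccc(C(=O)CC(C)C)c1O`: 122 nM
compound 3 `Cc1ccc(C(=O)O)cc1OCCCCOc1ccc(C(=O)CC(C)C)c(O)c1C`: 454 nM
compound 1 `Cc1c(OCCCCOc2cccc(C(=O)O)c2)ccc(C(=O)CC(C)C)c1C`: "not active" (no number reported)

In an assay on HEK293 cells for positive allosteric modulation of metabotropic glutamate receptor 2 (Rattus norvegicus), read by thallium flux, with a stated time of 2.5 min (on this read-out lower numbers stand for an effect already at smaller amounts and higher numbers for an effect only at larger amounts of compound), compound 3 gives 454 nM, the higher of the two numbers. Compound 2 gives 122 nM, and the change is a 3.7-fold higher number from compound 2 to compound 3 (0.57 log units; beyond the scatter). Compound 1 gives "not active" (no number reported), without a number. Compound 4 `Cc1c(OCCCCOc2cccc(C(=O)O)c2)ccc(C(=O)CC(C)C)c1O` differs from compound 3 by hydrogen in place of methyl on an aromatic carbon. For the measured compounds named here, no measured step removes this methyl alone; the one step that bears on it, a 3.7-fold higher number from compound 2 to compound 3 (0.57 log units; beyond the scatter), moved the carboxy group and added the methyl together, so the share of the methyl itself is unknown. For compound 4 a step within the scatter, in either direction, is therefore expected. For compound 4 the number in this assay is estimated at 500 nM, between 150 nM and 2000 nM. The expected step is a 1.1-fold higher number from compound 3 to compound 4 (0.04 log units; within the scatter).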

Compound 4, half-maximal effective concentration: 222 nM
The estimate for compound 4 lay 2.3-fold (0.35 log units) above the measured number; low and high end bracket the measured number.
By their numbers in this assay, from the lowest: compounds 2 and 4 (each within the scatter of the next); then compound 3.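

In this assay, hydrogen in place of methyl alone gives a 2.0-fold lower number from compound 3 to compound 4 (0.31 log units; beyond the scatter) and so separates the share of this methyl from the earlier combined change. With the methyl gone, the change from 4-carboxyphenyl to 3-carboxyphenyl, read in the listed direction as a 1.8-fold higher number from compound 2 to compound 4 (0.26 log units; within the scatter), stays within the scatter, so these two carboxy placements cannot be told apart here. No measurement offered here accounts for the difference the methyl makes. As far as these compounds go, it remains open whether a chlorine atom or an ethyl group on this aromatic carbon would behave like the methyl or like hydrogen.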